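Removing the Fluoro Group from Compound 3: An Expectation

The compounds below may be only part of what the source reports. "The series", "measured", "known", "first", "only" and "open" are said of these compounds alone.

Four compounds built on one shared core are compared here. Compound 1 `O=C(N/N=C/c1ccccc1)Nc1ccc(Oc2ccnc3[nH]ccc23)c(F)c1` in a functional assay on HepG2 cells (Homo sapiens) for antiproliferative activity, read by MTT assay, with a stated time of 72 h (a higher number here means a weaker inhibitor, a lower number a stronger inhibitor), gives 640 nM. Compound 2 `O=C(N/N=C/c1ccccc1)Nc1ccc(Oc2ccnc3[nH]ccc23)cc1` in this assay gives 750 nM. The difference between them is hydrogen in place of fluoro on an aromatic carbon, and the step was a 1.2-fold higher number from compound 1 to compound 2 (0.07 log units; within the scatter). Compound 3 `CN(C)CCn1cccc1/C=N/NC(=O)Nc1ccc(Oc2ccnc3[nH]ccc23)c(F)c1` differs from compound 1 by 1-(2-(dimethylamino)ethyl)-1H-pyrrol-2-yl in place of phenyl on a carbon with a double bond to nitrogen; in this assay compound 3 gives 8980 nM, and the step was a 14-fold higher number from compound 1 to compound 3 (1.15 log units; beyond the scatter), the largest movement among these three compounds. Compound 4 `CN(C)CCn1cccc1/C=N/NC(=O)Nc1ccc(Oc2ccnc3[nH]ccc23)cc1` has not yet been tested in this assay. Among the compounds with values here, it differs from compound 3 by hydrogen in place of fluoro on an aromatic carbon, which is the same change as the one from compound 1 to compound 2, made at a place described in exactly the same words. Because the earlier step of a 1.2-fold higher number from compound 1 to compound 2 (0.07 log units; within the scatter) stayed within the usual scatter, the step from compound 3 to compound 4 is expected to be about a 1.1-fold higher number from compound 3 to compound 4 (0.05 log units; within the scatter), with compound 3 as the starting point. Compound 4 is therefore estimated to give around 10000 nM in this assay, most likely between 5000 nM and 22000 nM.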

Compound 4, half-maximal inhibitory concentration: "not active" (no number reported)
For compound 4 the study gives words and no number, and the estimate cannot be compared.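

In this assay, within the data shown here, compound 4 is reported only as "not active", without a number, and no step from compound 3 to compound 4 can be read. No measurement shown here bears on this result. The compounds shown leave open how far replacing fluoro with hydrogen shifts the number when the 1-(2-(dimethylamino)ethyl)-1H-pyrrol-2-yl group is present.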